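A few compounds are considered here, and "the series" means these few. Any claim that something is new, unique, unknown or untested is made for them only; others in the source may bear on it.

Measured so far in the series:

compound 1, `CCOC(=O)c1c(C)[nH]c(=O)c(C#N)c1-c1ccc(Br)cc1`; in a functional assay on SK-OV-3 cells (Homo sapiens) for inhibition, read by MTT assay, with a stated time of 24 h (a higher number here means a weaker inhibitor, a lower number a stronger inhibitor), compound 1 gives > 100000 nM, which is a limit of the assay and not a number.
compound 2, `CCOC(=O)c1c(C)[nH]c(=O)c(C#N)c1-c1ccccc1Cl`; in this assay compound 2 gives > 100000 nM, likewise a limit of the assay.

Compound 2 therefore stands at the limit, as does every value shown so far (the limit of > 100000 nM in this assay, at which 2 of the 2 values shown sit). Going by the values given here, the single comparison between measured compounds, a step that the two limits leave unreadable from compound 1 to compound 2, yields nothing readable, since both ends sit at the limit.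

Compound 3, `CCOC(=O)c1c(C)[nH]c(=O)c(C#N)c1-c1ccco1`, differs from compound 2 in one place: furan-2-yl in place of 2-chlorophenyl on an aromatic carbon. Among the compounds with values here, no measured step bears on exchanging the aryl group for a furan-2-yl, and the one step that exists between compound 1 and compound 2 cannot be sized. With both neighbours at the limit, compound 3 is expected to remain there as well, the estimated step being a step that the limit leaves unreadable from compound 2 to compound 3, with no reading beyond the scatter. Compound 3 is estimated at 150000 nM in this assay, with an expected range from 30000 nM to 1000000 nM.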

Compound 3, half-maximal inhibitory concentration: 76000 nM
Compound 3: middle estimate off by 2.0-fold (0.30 log units), on the high side, within the range that was stated.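

In this assay, going by these compounds alone, compound 3, with furan-2-yl on the aromatic carbon opposite the ring nitrogen, gives 76000 nM as the first value at this position that is a number and not a limit. Against the two compounds carrying a substituted phenyl group, only floors can be read, as an at least 1.3-fold lower number from compound 2 to compound 3 (0.11 log units; that floor lies within the scatter) and an at least 1.3-fold lower number from compound 1 to compound 3 (0.11 log units; that floor lies within the scatter) and so the exchange for furan-2-yl is not shown to go beyond the scatter. The step between compound 1 and compound 2 cannot be read, and every comparison with compound 3 still rests on a limit: the limit of > 100000 nM in this assay, at which 2 of the 3 values shown sit.

Open at this position is how a thiophen-2-yl or an aminophenyl group would read. Also open, on these data alone, is what a carboxylic acid in place of the ethoxycarbonyl group would do to the value of compound 3.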